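Dropping the Chlorine from a Beta-Lactam Growth Inhibitor

The source may report more compounds than this note shows. Statements on the series, on what has been measured and on what is new or still open speak of the compounds shown alone.

Compound 1, with the structure `O=C1[C@@H](n2cc(-c3ccccc3)nn2)[C@@H](/C=C/c2ccccc2)N1c1ccc(Cl)cc1`, was tested in a functional assay on KB cells (Homo sapiens) for inhibition, tested at 100 uM (on this read-out lower numbers stand for less inhibition of growth and higher numbers for more inhibition of growth at the one concentration tested), and gave 79.3%. Among the two compounds measured, compound 1 stands highest; its only neighbour, compound 2, with the structure `COC(=O)c1nnn([C@@H]2C(=O)N(c3ccc(Cl)cc3)[C@@H]2/C=C/c2ccccc2)c1C(=O)OC`, gave 56.5% in this assay, a number lower by an amount beyond the usual scatter. Compound 2 differs from compound 1 in more than one place, so its value says nothing direct about a single change.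

Compound 3, with the structure `O=C1[C@@H](n2cc(-c3ccccc3)nn2)[C@@H](/C=C/c2ccccc2)N1c1ccccc1`, has not yet been measured. It differs from compound 1 by hydrogen in place of chloro on an aromatic carbon. For the measured compounds named here, no pair of measured compounds shows this change on its own, so the expected size of the step rests only on the shared core. A small step downward from compound 1 to compound 3, or none beyond the scatter, is expected, namely a number 9.3 percentage points lower from compound 1 to compound 3 (within the scatter). Compound 3 is therefore estimated to give 70% in this assay, expected to lie between 50% and 88%.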

Compound 3, percent growth inhibition at one concentration: 58.3%
Compound 3: middle estimate off by 11.7 percentage points, on the high side; the measured number falls inside the stated range.
By their numbers in this assay, from the lowest: compounds 2 and 3 (each within the scatter of the next); then compound 1.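

In this assay, for the compounds shown here, the change from 4-chlorophenyl to phenyl can now be read on its own for the first time, with the rest of the molecule held constant: a number 21 percentage points lower from compound 1 to compound 3 (beyond the scatter). The earlier compounds shown here could not show this, as compound 1 and compound 2 differ in more than one place. The chloro para to a large group therefore matters on this read-out, since replacing it with hydrogen gives less growth inhibition at the one concentration tested. Nothing available here explains why this step occurs.

Going by these compounds, whether a fluoro, a bromo or a methoxy group at this same place would keep the higher number of compound 1 remains open. Also open, on these data alone, is whether removing the chloro from compound 2 would give a step of similar size, since this single pair shows the change on one set of surrounding groups only.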